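The compounds below may be only part of what the source reports. "The series", "measured", "known", "first", "only" and "open" are said of these compounds alone.

Compound 1 `COc1cc(-c2nc(C(c3ccc(F)cc3)c3ccc(F)cc3)sc2CC(=O)O)ccn1` is one of three compounds tested in an in vitro functional assay on HEK285-7 cells for antagonist activity at prostaglandin D2 receptor 2 (Homo sapiens), read by BRET and beta-arrestin recruitment; a higher number here means a larger maximal response, a lower number a smaller maximal response. In this assay compound 1 reaches 60%. Among the measured compounds shown here, compound 2 `O=C(O)Cc1sc(C2COc3ccccc3O2)nc1-c1ccc(Cl)cc1` reaches 50% in this assay, a number that differs from the one for compound 1 by an amount within the usual scatter, so the two cannot be told apart. Compound 3 `O=C(O)Cc1sc(C(c2ccccc2)c2ccc(F)cc2)nc1-c1ccc(Cl)cc1` reaches 80% in this assay, a number higher than that of compound 1 by an amount beyond the scatter. For the measured compounds named here, no step between any of these measured pairs has been worked out, so only the bare numbers can be set side by side, and on them compound 1 stands second highest of the three.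

Compound 4 `Nc1cc(-c2nc(C(c3ccc(F)cc3)c3ccc(F)cc3)sc2CC(=O)O)cc(F)n1` has not yet been measured. It differs from compound 1 in one place: 2-amino-6-fluoropyridin-4-yl in place of 2-methoxypyridin-4-yl on an aromatic carbon. The rest of the shared core is unchanged. Going by the values given here, no measured pair shows this kind of change, so there is no basis for expecting a shift in either direction. The step that this estimate means, no change at the digits printed from compound 1 to compound 4 (within the scatter), is expected to be no change beyond the scatter. Compound 4 is therefore estimated to reach 60% in this assay, with a range from 40% to 80%.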

Compound 4, largest response reached (reported as efficacy), in percent of the reference or control that the assay uses: 30%
Beside the measured number, compound 4's estimate is 30 percentage points above it; the measured number lies below the stated range.
By their numbers in this assay, from the lowest: compound 4; then compounds 2 and 1 (each within the scatter of the next); then compound 3.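

This position on the shared core is not a silent one: on an aromatic carbon of the five-membered ring, 2-amino-6-fluoropyridin-4-yl in place of 2-methoxypyridin-4-yl gives, in this assay, a number 30 percentage points lower from compound 1 to compound 4 (beyond the scatter). Both groups have the same ring and the same count of heavy atoms, so a large shift here comes without any change in ring type or heavy-atom count. The entering group does bring a hydrogen-bond donor that the leaving group lacks, but nothing measured here explains the shift.

The step removes a methoxy group and adds both an amino group and a fluorine at once, so the compounds shown cannot divide the shift among them. A pyridine ring carrying the amino group alone, or the fluorine alone, remains an open comparison.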